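The source may hold more compounds than are shown below. What is called first, only, known or untested is meant among the compounds shown, and "the series" means these compounds.

Compound 1 `CCCC(C#CC(=O)OC)O/C=C/C(=O)OC`: 270 nM
Compound 2 `C#CCO/C=C/C(=O)OC`: > 100000 nM
Compound 3 `CCOC(=O)C#CC(O/C=C/C(=O)OCC)C(C)C`: 3000 nM

In a functional assay on HBL-100 cells (Homo sapiens) for antiproliferative activity, read by sulforhodamine B assay, with a stated time of 48 h (on this read-out higher numbers stand for weaker inhibition of growth and lower numbers for stronger inhibition of growth), compound 1 gives 270 nM, the lowest number among the compounds measured. Compound 3 gives 3000 nM, a much higher number than compound 1, and the gap between them lies beyond the usual scatter. Compound 2 reaches only a limit of the assay the limit of > 100000 nM in this assay, at which 1 of the 3 values shown sits, and so gives no number of its own.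

Compound 4 `COC(=O)C#CC(C)O/C=C/C(=O)OC` has not been measured. It differs from compound 1 in one place: hydrogen in place of ethyl on a saturated chain carbon, two bonds along the chain from an oxygen on an unsaturated carbon and a triple-bonded carbon. Shortening the chain on the same carbon, as seen in compound 3, went with weaker inhibition, so a moderate step in that direction is expected here, a 5.6-fold higher number from compound 1 to compound 4 (0.74 log units; beyond the scatter). Compound 4 is therefore estimated at 1500 nM, within a range of 400 nM to 6000 nM.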

Compound 4, concentration for 50% growth inhibition: 300 nM
Compound 4: middle estimate off by 5.0-fold (0.70 log units), on the high side, and the stated range ends above it.
By their numbers in this assay, from the lowest: compounds 1 and 4 (each within the scatter of the next); then compound 3. At a limit, above all of these: compound 2.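

Going from ethyl to hydrogen on this saturated chain carbon, which shortens propyl to methyl, gives a 1.1-fold higher number from compound 1 to compound 4 (0.05 log units; within the scatter) in this assay and so leaves the two compounds indistinguishable. For the compounds shown here, this is the first pair that differs in one place, and it shows that on this core the full propyl chain is not needed for this level of growth inhibition. Nothing given here explains why the two compounds match.

As far as these compounds go, whether a longer chain on this carbon would keep this level remains open. So does the effect of an amine or a carboxylic acid there.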